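The compounds below may be only part of what the source reports. "The series", "measured", "known", "first", "only" and "open" are said of these compounds alone.

Among the measured compounds shown here, in an assay on isolated protein for inhibition of STE20-like serine/threonine-protein kinase (Homo sapiens), read by thermal shift assay, tested at 10 uM (on this read-out lower numbers stand for weaker stabilisation of the target and higher numbers for stronger stabilisation of the target against heat), compound 2 `CC(C)(C)c1cc(NC(=O)Nc2ccccc2)n(-c2ccccc2)n1` gives 7.7 degrees C, the higher of the two numbers so far, while compound 1 `CCOc1ccc(NC(=O)Nc2cc(C(C)(C)C)nn2-c2ccccc2)cc1` gives 1.1 degrees C. The only measured step, a number 6.6 degrees C higher from compound 1 to compound 2 (beyond the scatter), concerns a group on the ring attached to the amide-type nitrogen. Compound 3 `CC(C)(C)c1cc(NC(=O)Nc2cc(F)cc(F)c2)n(-c2ccccc2)n1` alters that same ring in a different way: 3,5-difluorophenyl in place of phenyl on an amide-type nitrogen. For the measured compounds named here, no measured step shows fluorine on this ring, so the expectation stays close to compound 2. Compound 3 is expected to give 6.5 degrees C, between 3.5 degrees C and 9.5 degrees C. For compound 3 this means an expected step of a number 1.2 degrees C lower from compound 2 to compound 3 (beyond the scatter), possibly within the scatter.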

Compound 3, shift of the target's melting temperature: 3 degrees C
For compound 3 the middle estimate is 3.5 degrees C above the measured one; measured number below the stated range.
By their numbers in this assay, from the lowest: compound 1; then compound 3; then compound 2.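

In this assay, the ring on the amide-type nitrogen proves sensitive to fluorine as well as to ethoxy: 3,5-difluorophenyl in place of phenyl gives a number 4.7 degrees C lower from compound 2 to compound 3 (beyond the scatter), leaving plain phenyl with the highest number of the three rings shown. Set against 4-ethoxyphenyl, 3,5-difluorophenyl gives a number 1.9 degrees C higher from compound 1 to compound 3 (beyond the scatter), a modest gain. Nothing available explains why these rings differ. The compounds shown leave open whether a phenyl ring carrying a single fluorine, a chlorine or an amine would stay near compound 2 or fall towards compound 3.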